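The source may hold more compounds than are shown below. What is called first, only, known or untested is meant among the compounds shown, and "the series" means these compounds.

In an ADME assay on MT4 cells (Homo sapiens) for cytotoxicity, read by MTT assay (a higher number here means that more compound is tolerated, a lower number that less compound is tolerated), compound 1 `CCOC(=O)/C(O)=C/C(=O)c1cn(Cc2ccc(F)cc2)c2ccc(OC)cc12` gives 126000 nM. Two relatives were tested in the same way: compound 2 `COc1ccc(OC)c2c1c(C(=O)/C=C(\O)C(=O)O)cn2Cc1ccc(F)cc1` gives 213000 nM and compound 3 `COc1cccc2c(C(=O)/C=C(\O)C(=O)O)cn(Cc3ccc(F)cc3)c12` gives 82900 nM. Compound 1 lies within the usual scatter of each of these two, so it cannot be ranked against either.

The next compound, compound 4 `COc1ccc2c(c1)c(C(=O)/C=C(\O)C(=O)O)cn2Cc1ccc(F)cc1`, differs from compound 1 by one small edit: hydrogen in place of ethyl on an oxygen next to a carbonyl group. In words, this is hydrogen in place of ethyl on an oxygen next to a carbonyl group, which turns ethoxycarbonyl into carboxy. Among the compounds with values here, no measured pair shows this change on its own. Compound 2 and compound 3 already carry the carboxy group, but they also differ from compound 1 elsewhere. Within the data shown here, the only measured step, hydrogen in place of methoxy on an aromatic carbon, is a different edit and was modest: a 2.6-fold lower number from compound 2 to compound 3 (0.41 log units; beyond the scatter). That step shows how far the number can move between two compounds with the carboxy group. Since compound 1 stands within the scatter of both, no step beyond the scatter is expected in this assay, in either direction. The expected change is a 1.0-fold higher number from compound 1 to compound 4 (0.01 log units; within the scatter). For compound 4, the estimated value is 130000 nM, with an expected range from 60000 nM to 250000 nM.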

Compound 4, half-maximal cytotoxic concentration: 63600 nM
Compound 4: middle estimate off by 2.0-fold (0.31 log units), on the high side; low and high end bracket the measured number.
By their numbers in this assay, from the lowest: compounds 4, 3, 1 and 2 (each within the scatter of the next, the first and the last beyond it).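

Within the data shown here, this is the first pair in which the change from ethyl to hydrogen on an oxygen next to a carbonyl group can be read on its own, with the rest of the molecule unchanged. In this assay, the result is a 2.0-fold lower number from compound 1 to compound 4 (0.30 log units; within the scatter), so turning ethoxycarbonyl into carboxy on the core of compound 1 gives a difference that cannot be told apart from the ordinary spread of repeated measurements, and the two compounds cannot be ranked against each other. The data therefore show that, on this core, the ethyl group can be exchanged for hydrogen without a readable shift in the amount of compound the cells tolerate, and no measurement given here offers an explanation for the two numbers.

The compounds shown leave open whether a methyl group or a longer chain such as butyl on the same oxygen, or an amine in its place, would also stay close to compound 1. They also leave open whether the same edit would read the same way on a core with its methoxy group placed differently.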